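Neopentyl to fluorobenzyl on the ring nitrogen: stability outlook

The source may report more compounds than this note shows. Statements on the series, on what has been measured and on what is new or still open speak of the compounds shown alone.

Measured compounds:
- compound 1, `COCN(c1ccc2c(c1)S(=O)(=O)N=C(c1c(O)c(-c3cccs3)nn(CCC(C)C)c1=O)N2)S(C)(=O)=O`, 0.183 h
- compound 2, `CCC(C)(C)c1nn(CCC(C)C)c(=O)c(C2=NS(=O)(=O)c3cc(NS(C)(=O)=O)ccc3N2)c1O`, 0.1 h
- compound 3, `CC(C)(C)Cn1nc(-c2cccs2)c(O)c(C2=NS(=O)(=O)c3cc(NS(C)(=O)=O)ccc3N2)c1=O`, > 1 h

In an in vitro ADME assay on microsomes from liver (Homo sapiens) for metabolic stability, tested at 5 uM (a lower number here means that the compound disappears faster, a higher number that the compound lasts longer), compound 1 gives 0.183 h and compound 2 gives 0.1 h. Among the measured compounds shown here, for compound 3 the assay returns only a limit, > 1 h, so no number is known for it; it is the one compound of the three that sits at the limit of > 1 h in this assay, at which 1 of the 3 values shown sits. Compound 3 therefore stands at the upper edge of what this assay reports here, with compound 1 and compound 2 both well beneath it.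

Compound 4, `CS(=O)(=O)Nc1ccc2c(c1)S(=O)(=O)N=C(c1c(O)c(-c3cccs3)nn(Cc3ccc(F)cc3)c1=O)N2`, differs from compound 3 in one place: 4-fluorophenyl in place of tert-butyl on a saturated chain carbon bound to an aromatic nitrogen. For the measured compounds named here, no measured pair in the set isolates this change, so no size can be read from the data; the step of an at least 1.2-fold lower number from compound 3 to compound 4 (0.09 log units; that floor lies within the scatter) is expected to be small, within the scatter or at most a modest decrease, since the rest of the core is kept. Compound 4 is thus estimated at 0.8 h, between 0.3 h and 2 h, with a fair chance that this assay again reports only a limit.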

Compound 4, half-life: > 1 h
Compound 4: no number, only a limit (the forecaster's own chance of this, stated with the estimate: 40%); middle value at least 1.2-fold (0.09 log units) from the limit.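

In this assay, among the compounds shown here, compound 4 returns > 1 h, a limit and not a number, as compound 3 also does, so no step between compound 3 and compound 4 can be read. The compounds shown leave open whether neopentyl and 4-fluorobenzyl differ in half-life at all.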